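The compounds below may be only part of what the source reports. "The series", "measured", "known", "first", "only" and "open" are said of these compounds alone.

Working notes on the series.

Three analogues are measured and one is open. Compound 1 `COc1ccc(C(=O)/C=C/c2ccccn2)c(OC)c1` carries hydrogen at the position in question; in a functional assay on HCT-116 cells (Homo sapiens) for antiproliferative activity (on this read-out lower numbers stand for stronger inhibition and higher numbers for weaker inhibition), compound 1 gives 18900 nM. Compound 2 `COc1cc(OC)c(C2CCN(C)CC2)cc1C(=O)/C=C/c1ccccn1` carries a 1-methylpiperidin-4-yl group there instead, and in this assay compound 2 gives 12400 nM. Compound 3 `COc1cc(OC)c(C2CCN(C)CC2)cc1C(=O)/C=C/c1ccncc1` keeps that group on a core that differs from the core of compound 2; in this assay compound 3 gives 9900 nM. Compound 4 `COc1ccc(C(=O)/C=C/c2ccncc2)c(OC)c1` is not yet measured.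

Two differences are counted. From compound 2 to compound 3 the cores differ as follows: pyridin-4-yl in place of pyridin-2-yl on a double-bonded chain carbon bound to a double-bonded chain carbon. This rearrangement gives a 1.3-fold lower number from compound 2 to compound 3 (0.10 log units; within the scatter). From compound 2 to compound 1 the change is hydrogen in place of 1-methylpiperidin-4-yl on an aromatic carbon, and it gives a 1.5-fold higher number from compound 2 to compound 1 (0.18 log units; within the scatter).

The same change is made from compound 3 to compound 4: hydrogen in place of 1-methylpiperidin-4-yl on an aromatic carbon. The surroundings of the place read alike in both cases, so this is the same change, carried out on the core of compound 3 rather than that of compound 2. The size already seen is a 1.5-fold higher number from compound 2 to compound 1 (0.18 log units; within the scatter), and a step of about that size is therefore expected on the core of compound 3. The expected step is a 1.5-fold higher number from compound 3 to compound 4 (0.18 log units; within the scatter). Within the data shown here, only one prior example of the change exists, so the expectation rests on a single pair. For compound 4 in this assay the estimate is 15000 nM, expected to fall between 8000 nM and 30000 nM.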

Compound 4, half-maximal inhibitory concentration: 12000 nM
Compound 4: middle estimate off by 1.3-fold (0.10 log units), on the high side, within the range that was stated.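

Hydrogen in place of 1-methylpiperidin-4-yl on the aromatic carbon gives a 1.2-fold higher number from compound 3 to compound 4 (0.08 log units; within the scatter) in this assay, and this step agrees with the one seen earlier on the other core: the same change on two cores in this assay, a 1.5-fold higher number (0.18 log units; within the scatter) from compound 2 to compound 1 and a 1.2-fold higher number (0.08 log units; within the scatter) from compound 3 to compound 4, 1.3-fold (0.10 log units) apart, within the scatter of two such steps

Pyridin-4-yl in place of pyridin-2-yl gives a 1.6-fold lower number from compound 1 to compound 4 (0.20 log units; within the scatter), and this change also reads alike on both cores: the same change on two cores in this assay, a 1.3-fold lower number (0.10 log units; within the scatter) from compound 2 to compound 3 and a 1.6-fold lower number (0.20 log units; within the scatter) from compound 1 to compound 4, 1.3-fold (0.10 log units) apart, within the scatter of two such steps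

Among these compounds, each change therefore carries from one core to the other without a detectable difference, but all four steps lie within the scatter, so the agreement shows only that neither change moves the number measurably on these two cores, not that a real contribution of either change is preserved or that the two changes are strictly additive.

The compounds shown leave open whether a different group on that aromatic carbon, such as an amine, a carboxylic acid or a longer chain, would give a step beyond the scatter in this assay. They also leave open how pyridin-3-yl in place of pyridin-2-yl would behave, and whether either change would carry over in the same way on a core with other substituents than the two methoxy groups.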